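A Phenyl-to-Chloro Swap and Its Expected Effect

This account rests on a few compounds, and the source may have more. Where it says the series, first, only, none or still open, it means among the compounds named here.

Measured compounds:
- compound 1 `CCN(CC)c1ccc(NC(=O)c2c(-c3ccccc3-c3ccccc3)noc2C)cc1`: 6300 nM
- compound 2 `CCN(CC)c1ccc(NC(=O)c2c(-c3c(Cl)cccc3Cl)noc2C)c(C(F)(F)F)c1`: > 10000 nM

Two compounds were tested in a functional assay on CHO K cells for inhibition of growth hormone secretagogue receptor type 1 (Homo sapiens), read by FLIPR; on this read-out higher numbers stand for weaker inhibition and lower numbers for stronger inhibition. For the measured compounds named here, compound 1 `CCN(CC)c1ccc(NC(=O)c2c(-c3ccccc3-c3ccccc3)noc2C)cc1` gives 6300 nM in this assay, and this is the only numerical value available. Compound 2 `CCN(CC)c1ccc(NC(=O)c2c(-c3c(Cl)cccc3Cl)noc2C)c(C(F)(F)F)c1` gives > 10000 nM in this assay, which is a limit of the assay rather than a number, so the limit of > 10000 nM in this assay, at which 1 of the 2 values shown sits, applies to it. Compound 1 therefore stands as the sole measured point, itself a weak inhibitor.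

Compound 3 `CCN(CC)c1ccc(NC(=O)c2c(-c3ccccc3Cl)noc2C)cc1` has not yet been measured. It differs from compound 1 by chloro in place of phenyl on an aromatic carbon. Going by the values given here, no step between measured compounds covers this change, and compound 2 differs from compound 1 in more than one place, so its limit offers no direct guide. Given this, the step from compound 1 to compound 3 is expected to be small, no further than the scatter, and without a clear direction. Compound 3 is expected to show 6000 nM in this assay, within a range from 1500 nM to 20000 nM, a step of a 1.1-fold lower number from compound 1 to compound 3 (0.02 log units; within the scatter).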

Compound 3, half-maximal inhibitory concentration: 250 nM
For compound 3 the middle estimate is 24-fold (1.38 log units) above the measured one; the whole stated range lies above it.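

In this assay, chloro in place of phenyl on this aromatic carbon, ortho to a large group, gives a 25-fold lower number from compound 1 to compound 3 (1.40 log units; beyond the scatter) and shows that this position is far from indifferent to what it carries. For the compounds shown here, the earlier compounds gave no comparison that differed in one place, so this pair is the first direct reading of any change on the core, and it shows that the phenyl is not needed for inhibition on this read-out: a single chlorine atom on the same carbon gives the much lower number. The pair fixes the size and direction of the change, but nothing shown here bears on why the step is so large.

As far as these compounds go, it remains open how hydrogen, fluoro, methyl or methoxy on this same carbon would compare with chloro, and so whether the gain belongs to chloro itself or simply to the departure of phenyl. From the compounds shown here alone, it is also open whether a step of this size would hold if a morpholine or a piperidine took the place of the diethylamino group elsewhere on the shared core.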